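This account rests on a few compounds, and the source may have more. Where it says the series, first, only, none or still open, it means among the compounds named here.

Working notes on the series, read in an ADME assay on J774.A1 cells (Mus musculus) for cytotoxicity, read by MTT assay, with a stated time of 72 h; a higher number here means that more compound is tolerated, a lower number that less compound is tolerated. Going by the values given here, compound 1 `COc1ccc(-c2cc(-c3ccc(C4NC(=O)c5ccccc5N4)cc3)nc(N)n2)cc1` gives 178000 nM, the only actual number so far. Compound 2 `CC(C)c1ccc(C(Nc2ccc(C3(C)NC(=O)c4ccccc4N3)cc2)c2nnnn2C2CCCCC2)cc1` reads > 400000 nM, which is a limit of the assay and not a number.

Compound 3 `COc1cccc(-c2cc(-c3ccc(C4NC(=O)c5ccccc5N4)cc3)nc(N)n2)c1OC` keeps the core of compound 1 and carries 2,3-dimethoxyphenyl in place of 4-methoxyphenyl on an aromatic carbon, next to the ring nitrogen (2,3-dimethoxyphenyl in place of 4-methoxyphenyl on an aromatic carbon). Among the compounds with values here, no measured pair covers a change at this place. With compound 1 at 178000 nM as the only anchor, no shift beyond the usual scatter is expected in this assay, in either direction. The expected change is small, a 1.1-fold higher number from compound 1 to compound 3 (0.03 log units; within the scatter). For compound 3 the estimated value is 190000 nM, with an expected range of 80000 nM to 400000 nM.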

Compound 3, half-maximal cytotoxic concentration: > 400000 nM
Compound 3: no number, only a limit; the forecaster's own chance of this, stated with the estimate: 15%; at least 2.1-fold (0.32 log units) between middle value and limit.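

In this assay, compound 3 reads > 400000 nM, a limit of the assay and not a number. Going by these compounds alone, this gives the first reading of a change at this place, on an aromatic carbon next to the ring nitrogen: 2,3-dimethoxyphenyl in place of 4-methoxyphenyl gives an at least 2.2-fold higher number from compound 1 to compound 3 (0.35 log units; beyond the scatter). The step fixes a direction and a lower bound on its size, but not the full size of the change, and the new reading sits at the top of what the series can show: the limit of > 400000 nM in this assay, at which 2 of the 3 values shown sit.

The compounds shown do not separate the effect of the extra methoxy group from that of the changed arrangement of methoxy groups on the phenyl ring. On these data alone, how a phenyl ring carrying an amine or a carboxylic acid at this place would read in this assay also stays open.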